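Swapping 4-Chlorophenyl for 5-Methylfuran-2-yl: an Estimate

The source may hold more compounds than are shown below. What is called first, only, known or untested is meant among the compounds shown, and "the series" means these compounds.

Compound 1 `COc1nc(-c2cc3ccccc3o2)cc(-c2ccc(Cl)cc2)c1C#N` gives 286000 nM in a functional assay on aorta (strain Wistar) for inhibition, with Thoracic aorta (Rattus norvegicus) as the target; a higher number here means a weaker inhibitor, a lower number a stronger inhibitor.
Compound 2 `CCOc1nc(-c2cc3ccccc3o2)cc(-c2ccc(Cl)cc2)c1C#N` gives 221000 nM in this assay.
Compound 3 `CCOc1nc(-c2cc3ccccc3o2)cc(-c2cccs2)c1C#N` gives 308000 nM in this assay.

All three numbers are very high, so every measured compound is a weak inhibitor in this assay. The number for compound 1 lies between those of compound 2 and compound 3, and all three lie within the usual scatter of one another, so none can be told apart with confidence. The two steps that connect them confirm this: a 1.3-fold lower number from compound 1 to compound 2 (0.11 log units; within the scatter) and a 1.4-fold higher number from compound 2 to compound 3 (0.14 log units; within the scatter).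

Compound 4 `COc1nc(-c2cc3ccccc3o2)cc(-c2ccc(C)o2)c1C#N` has not yet been measured. It differs from compound 1 in one place: 5-methylfuran-2-yl in place of 4-chlorophenyl on an aromatic carbon. The step from compound 2 to compound 3 bears directly on this, since there too 4-chlorophenyl gave way to a five-membered aromatic ring with one hetero atom on the same aromatic carbon, and the result was a 1.4-fold higher number from compound 2 to compound 3 (0.14 log units; within the scatter). The step from compound 1 to compound 2 touches a different part of the molecule and is less informative, but it was also within the scatter.

On that basis compound 4 is expected to show a 1.1-fold higher number from compound 1 to compound 4 (0.05 log units; within the scatter), no step beyond the scatter. The estimate for compound 4 is 320000 nM, with a range of 150000 nM to 700000 nM.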

Compound 4, half-maximal inhibitory concentration: 285000 nM
Beside the measured number, compound 4's estimate is 1.1-fold (0.05 log units) above it; measured number inside the range.
By their numbers in this assay, from the lowest: compounds 2, 4, 1 and 3 (each within the scatter of the next).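

In this assay, putting 5-methylfuran-2-yl where 4-chlorophenyl stood gives a 1.0-fold lower number from compound 1 to compound 4 (0.00 log units; within the scatter), so on this aromatic carbon, opposite the ring nitrogen and ortho to a cyano group, these two groups cannot be told apart. The earlier swap at this carbon, with thiophen-2-yl as the incoming ring, gave a 1.4-fold higher number from compound 2 to compound 3 (0.14 log units; within the scatter), and that pair carries a different chain on the oxygen; across the compounds shown, then, two different five-membered aromatic rings, each with one hetero atom, have replaced 4-chlorophenyl with every step inside the scatter, and the new result adds a ring with a methyl group on it and with oxygen in place of sulfur. Nothing available here gives a reason for this flat result.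

Going by these compounds, all four compounds are weak inhibitors, so it remains open whether any group on this aromatic carbon can move the number beyond the scatter, for example an amine or a carboxylic acid in place of the aromatic ring. On these data alone, it is equally open whether a much longer chain on the oxygen of the methoxy group would do so.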